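The compounds below may be only part of what the source reports. "The series", "measured", "known", "first", "only" and "open" are said of these compounds alone.

Measured compounds:
Compound 1 `COc1ccc(Cn2cnc3c(N(C)c4ccc(OC)cc4)ncnc32)cc1` gives > 100000 nM in a functional assay on AGS cells (Homo sapiens) for antiproliferative activity, read by MTT assay, with a stated time of 48 h; on this read-out higher numbers stand for weaker inhibition of growth and lower numbers for stronger inhibition of growth.
Compound 2 `COc1ccc(Cn2cnc3c(N(C)c4ccc(OC)cc4)nc(Cl)nc32)cc1` gives > 100000 nM in this assay.
Compound 3 `COc1ccc(Cn2cnc3c(Cl)ncnc32)cc1OC` gives > 100000 nM in this assay.

Compound 1 reaches only a limit of the assay in this assay, not a number. Compound 2 likewise returns only a limit of the assay. Compound 2 differs from compound 1 by chloro in place of hydrogen on an aromatic carbon. The step that the two limits leave unreadable from compound 1 to compound 2 cannot be read, since both values sit at the limit of > 100000 nM in this assay, at which 3 of the 3 values shown sit. Compound 3 also gives only a limit of the assay in this assay.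

Compound 4 `COc1ccc(Cn2cnc3c(Cl)nc(Cl)nc32)cc1OC` has not yet been measured. It differs from compound 3 by chloro in place of hydrogen on an aromatic carbon. This is the same kind of change as that from compound 1 to compound 2, though the surroundings are not identical: in compound 2 the entering chloro sits meta to a large group, whereas in compound 4 it sits meta to a chloro group (1 heavy atom). How the core of compound 3 differs from the core of compound 1 is not broken down here.

Beside the unreadable step that the two limits leave unreadable from compound 1 to compound 2, the step from compound 3 to compound 4 is expected to be small, estimated as a number no higher from compound 3 to compound 4 (the limit leaves the size open), because compound 3 gives > 100000 nM and the same kind of change left compound 2 at the limit. Compound 4 is therefore expected to give about 100000 nM in this assay, estimated to lie between 30000 nM and 300000 nM, with a real chance that only a limit is again reported.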

Compound 4, concentration for 50% growth inhibition: 11000 nM
For compound 4 the middle estimate is 9.1-fold (0.96 log units) above the measured one; measured number outside the range, below it.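

In this assay, chloro in place of hydrogen on the core of compound 3 gives an at least 9.0-fold lower number from compound 3 to compound 4 (0.95 log units; beyond the scatter), so on this core the change goes with stronger inhibition of growth, and the true size of the step may be larger still. The same kind of change on the core of compound 1 cannot be read, because both of its values sit at a limit: the limit of > 100000 nM in this assay, at which 3 of the 4 values shown sit. Compound 2 gives > 100000 nM, which is a limit of the assay and not a number, so this series offers a single readable step on a single core and does not show that the change carries from one core to another.

The compounds shown leave open whether the effect belongs to chloro itself, since no other group, such as an amine or a nitrile, stands on that same aromatic carbon between the two ring nitrogen atoms. Among the compounds shown here, they also leave open whether the chloro group already present on compound 3 is needed for the step, since no compound shows the entering chloro on the core of compound 3 with an amine in that other place.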